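Swapping the triazolyl for a methylpyrazolyl in compound 4

The compounds below may be only part of what the source reports. "The series", "measured", "known", "first", "only" and "open" are said of these compounds alone.

Of the compounds shown here, three built on a shared core have been measured in a physicochemical assay for lipophilicity; a higher number here means a more lipophilic compound, a lower number a more polar compound. Compound 1 `O=S(=O)(Nc1ccncn1)c1ccc2c(c1)OCC[C@@H]2c1ccc(C(F)(F)F)cc1-c1ccc(F)cn1` gives 3, compound 3 `O=S(=O)(Nc1nccs1)c1ccc2c(c1)OCC[C@@H]2c1ccc(C(F)(F)F)cc1-c1ccc(F)cn1` gives 3.5, and compound 2 `O=S(=O)(Nc1nccs1)c1ccc2c(c1)OCC[C@H]2c1ccc(C(F)(F)F)cc1-n1ccnn1` gives 2.3, the lowest of the three. Among the compounds with values here, the only single-point step among them, a number 0.50 log units higher from compound 1 to compound 3 (beyond the scatter), concerns the sulfonamide nitrogen and not the ring position changed here.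

Compound 4 `Cn1nccc1-c1cc(C(F)(F)F)ccc1[C@@H]1CCOc2cc(S(=O)(=O)Nc3nccs3)ccc21` is not yet measured. Relative to compound 2 the change is 1-methyl-1H-pyrazol-5-yl in place of 1H-1,2,3-triazol-1-yl on an aromatic carbon. Within the data shown here, no measured step covers this exact exchange; the nearest guide is that compound 2 and compound 3 differ at this same aromatic carbon, and compound 2 gives 2.3 while compound 3 gives 3.5. With the ring of 3 hetero atoms and 3 hydrogen-bond acceptors leaving and a ring of 2 hetero atoms and 2 hydrogen-bond acceptors entering, a rise beyond the scatter is expected, though smaller than the gap to compound 3. The expected step is a number 0.70 log units higher from compound 2 to compound 4 (beyond the scatter). Compound 4 is therefore estimated at 3, within 2.6 to 3.5.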

Compound 4, distribution coefficient: 2.2
Compound 4: middle estimate off by 0.80 log units, on the high side; measured number outside the range, below it.
By their numbers in this assay, from the lowest: compounds 4 and 2 (each within the scatter of the next); then compound 1; then compound 3.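

In this assay, the exchange at this aromatic carbon, ortho to a large group and meta to a trifluoromethyl group, gives a number 0.10 log units lower from compound 2 to compound 4 (within the scatter), so the two five-membered rings cannot be told apart here even though they differ in heavy atoms, hetero atoms and hydrogen-bond acceptors. Having fewer hetero atoms in the entering ring therefore does not by itself bring compound 4 toward compound 3, which gives 3.5, so the difference in hetero atoms alone does not set the number at this position. Nothing shown offers a reason for this result.

Going by these compounds, it remains open whether an amine or a carboxylic acid on this aromatic carbon, or a longer chain in place of the methyl on the pyrazole, would shift the number. On these data alone, it is also open whether the same exchange would read alike with pyrimidin-4-yl in place of 1,3-thiazol-2-yl on the sulfonamide nitrogen.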